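Chloro to Methoxy Swap in a Small Cytotoxicity Series

The source may hold more compounds than are shown below. What is called first, only, known or untested is meant among the compounds shown, and "the series" means these compounds.

Compound 1 `COCOc1cc(/C=C/C(=O)OCC(=O)Nc2ccc(OC)cc2)ccc1OCc1ccccc1`: in a functional assay on ECa-109 cells (Homo sapiens) for cytotoxicity, read by MTT assay, with a stated time of 72 h (a lower number here means a stronger inhibitor, a higher number a weaker inhibitor), compound 1 gives > 200000 nM, which is a limit of the assay and not a number.
Compound 2 `COCOc1cc(/C=C/C(=O)OCC(=O)Nc2ccc(Cl)cc2)ccc1OCc1ccccc1`: in this assay compound 2 gives > 200000 nM, again a limit and not a number.
Compound 3 `O=C(COC(=O)/C=C/c1ccc(O)c(O)c1)Nc1ccc(Cl)cc1`: in this assay compound 3 gives 175000 nM.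

Compound 4 `COc1ccc(NC(=O)COC(=O)/C=C/c2ccc(O)c(O)c2)cc1` has not yet been measured. It differs from compound 3 by methoxy in place of chloro on an aromatic carbon. The same change, (methoxy in place of chloro on an aromatic carbon), leads from compound 2 to compound 1, and there the step is a step that the two limits leave unreadable from compound 2 to compound 1 because of the limit of > 200000 nM in this assay, at which 2 of the 3 values shown sit. How the core of compound 3 differs from that of compound 2 is not broken down here, so the earlier pair gives no readable size to carry over; it shows only that both partners stayed at the limit. Compound 3 sits close to that limit as well. The expected step from compound 3 to compound 4 is a 1.1-fold higher number from compound 3 to compound 4 (0.06 log units; within the scatter), resting on the fact that compound 1 and compound 2 gave no sign that the swap moves potency far. Compound 4 is therefore estimated at 200000 nM, somewhere between 90000 nM and 450000 nM, with a fair chance that only a limit is reported.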

Compound 4, half-maximal inhibitory concentration: 190000 nM
Compound 4: middle estimate off by 1.1-fold (0.02 log units), on the high side; the measured number falls inside the stated range.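

In this assay, putting methoxy in place of chloro on the core of compound 3 gives a 1.1-fold higher number from compound 3 to compound 4 (0.04 log units; within the scatter), so on this core the swap leaves no readable change in potency. The same swap on the core of compound 2 cannot be read, and compound 1 and compound 2 each give a limit and not a number, so no size can be compared across the two cores, because both members of that pair sit at the assay's limit: the limit of > 200000 nM in this assay, at which 2 of the 4 values shown sit. The result therefore shows that the swap made no readable difference in one readable pair, but it does not show that the swap would behave the same way on another core, or in a compound with a much lower number.

The compounds shown leave open what happens when an amine, a carboxylic acid or a longer chain such as butoxy stands in place of chloro on that aromatic carbon. They also leave open whether any such group would move the number beyond the usual scatter in this assay.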